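Heptyl urea pair: the drawn configuration flips

The compounds below may be only part of what the source reports. "The series", "measured", "known", "first", "only" and "open" are said of these compounds alone.

The set is three ureas measured in an ADME assay on the whole organism with Oryza sativa as the target, tested at 10 uM; on this read-out higher numbers stand for a weaker effect at the one concentration tested and lower numbers for a stronger effect. Compound 1 `CC(C)c1ccc(NC(=O)N[C@@H](C)c2ccccc2)cc1` gives 86%; compound 2 `CCCCCc1ccc(NC(=O)N[C@@H](C)c2ccccc2)cc1` gives 93%; compound 3 `CCCCCCCc1ccc(NC(=O)N[C@H](C)c2ccccc2)cc1` gives 100%. Among the measured compounds shown here, the one step with a single change is a number 7 percentage points higher from compound 1 to compound 2 (within the scatter). Compound 3 stands highest of the three numbers: compound 2 lies nearest, with a gap that is within the scatter, and compound 1 lies furthest, with a gap that is beyond the scatter.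

The step now followed leads from compound 3 to compound 4 `CCCCCCCc1ccc(NC(=O)N[C@@H](C)c2ccccc2)cc1`. The structures differ in this way: the two compounds have the same atoms and bonds and differ only in configuration as drawn: 1 of 1 stereo elements differ; a stereocentre at a saturated chain carbon is drawn R in compound 3 and S in compound 4. For the measured compounds named here, no measured step in this set alters configuration alone; the only step, the pentyl for isopropyl change, concerns a chain, and its size was within the scatter. There is therefore nothing in the data that fixes the size or direction of a step in this assay for this change, and a step not beyond the scatter is the neutral expectation. Compound 4 is accordingly estimated at 93%, with a range from 75% to 100%, which means an expected step of a number 7 percentage points lower from compound 3 to compound 4 (within the scatter).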

Compound 4, a percentage reported as activity, at one concentration (the size of the read-out at that concentration, not a potency): 99%
Beside the measured number, compound 4's estimate is 6 percentage points below it, within the range that was stated.
By their numbers in this assay, from the lowest: compounds 1, 2, 4 and 3 (each within the scatter of the next, the first and the last beyond it).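

Flipping the stereocentre at the saturated chain carbon gives a number 1 percentage points lower from compound 3 to compound 4 (within the scatter) in this assay, the first step in the set that concerns configuration alone, and this reading rests on one fact: the fact that compounds 3 and 4 differ only in the configuration as drawn. Compound 4 also connects the chains in single steps: ethyl in place of hydrogen on the saturated chain carbon gives a number 6 percentage points higher from compound 2 to compound 4 (within the scatter), whereas heptyl in place of isopropyl gives a number 13 percentage points higher from compound 1 to compound 4 (beyond the scatter). Of the single changes shown so far, only the last lies beyond the scatter.

As far as these compounds go, whether the same flip would matter in the isopropyl or pentyl compounds remains open. So does what a longer chain such as nonyl, or an amine or a carboxylic acid in place of the heptyl, would give on this read-out.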